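This account rests on a few compounds, and the source may have more. Where it says the series, first, only, none or still open, it means among the compounds named here.

Compounds measured:
compound 1 `Cn1c(=O)c2c(nnn2C2CCCCC2O)n(C)c1=O` with 114000 nM
compound 2 `CCCn1c(=O)c2c(nnn2C2CCCC2)n(CCC)c1=O` with 340 nM
compound 3 `CCCn1c(=O)c2c(nnn2-c2ccc(Cl)cc2N)n(CCC)c1=O` with 44000 nM

The three compounds share one core and differ in the group on the aromatic nitrogen of the triazole ring and in the two chain substituents. In an assay on cell membranes from brain for displacement of a labelled ligand from adenosine receptor A1 (Bos taurus) (on this read-out lower numbers stand for stronger inhibition and higher numbers for weaker inhibition), compound 2 gives 340 nM, the lowest number of the three. Compound 3 stands second highest, with compound 1 nearest at a higher number and compound 2 furthest away. Going by the values given here, the only single-place step among the measured compounds is a 130-fold higher number from compound 2 to compound 3 (2.11 log units; beyond the scatter).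

Compound 4 `CCCn1c(=O)c2c(nnn2C2CCCCC2O)n(CCC)c1=O` has not been measured. It differs from compound 3 by 2-hydroxycyclohexyl in place of 2-amino-4-chlorophenyl on an aromatic nitrogen. Among the compounds with values here, no measured step covers this exact exchange; the step from compound 2 to compound 3 shows that the aryl group carries a large penalty relative to cyclopentyl, and compound 1, which bears the same 2-hydroxycyclohexyl group but shorter chains, gives 114000 nM. Compound 4 is therefore expected to fall between these extremes, with a 15-fold lower number from compound 3 to compound 4 (1.17 log units; beyond the scatter) as the anticipated step. The estimate for compound 4 in this assay is 3000 nM, with a range from 800 nM to 15000 nM.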

Compound 4, inhibition constant: 1800 nM
For compound 4 the middle estimate is 1.7-fold (0.22 log units) above the measured one; the range from low to high includes it.
By their numbers in this assay, from the lowest: compound 2; then compound 4; then compound 3; then compound 1.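

In this assay the position on the aromatic nitrogen now carries a third group with the two chains unchanged, and replacing the aryl group with 2-hydroxycyclohexyl gives a 24-fold lower number from compound 3 to compound 4 (1.39 log units; beyond the scatter) and so recovers most of the loss seen with 2-amino-4-chlorophenyl. The new group still falls short of cyclopentyl, with a 5.3-fold higher number from compound 2 to compound 4 (0.72 log units; beyond the scatter) as a modest cost, so this position accepts a six-membered non-aromatic ring bearing a hydroxyl group far better than the substituted aromatic ring. The exchange replaces the aromatic ring and its substituents together, so the step belongs to the whole group, and nothing available bears on the reason for either step.

As far as these compounds go, whether the gap to cyclopentyl comes from ring size or from the hydroxyl group stays open, and a plain cyclohexyl group would separate the two. Also open, from the compounds shown here alone, is how much of the aryl penalty belongs to the amino group and the chlorine rather than to the ring itself, which an unsubstituted phenyl group would address, and whether an amine or a methoxy group could stand in for the hydroxyl group.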